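Reversing the dihydroxyphenyl step toward a bromophenyl analogue

The source may report more compounds than this note shows. Statements on the series, on what has been measured and on what is new or still open speak of the compounds shown alone.

Compound 1 `C/C(=N\NC(=O)COc1cccc2ccccc12)c1cccc([N+](=O)[O-])c1` carries a 3-nitrophenyl on the carbon with a double bond to nitrogen, and in an ADME assay on HEL cells (Homo sapiens) for cytotoxicity (on this read-out higher numbers stand for lower toxicity in this test and lower numbers for higher toxicity in this test), compound 1 gives 20 ug/mL. Compound 2 `C/C(=N\NC(=O)COc1cccc2ccccc12)c1ccc([N+](=O)[O-])cc1` bears a 4-nitrophenyl in that place, and in this assay compound 2 gives 100 ug/mL, so that a 5.0-fold higher number from compound 1 to compound 2 (0.70 log units; beyond the scatter). Compound 3 `C/C(=N\NC(=O)COc1cccc2ccccc12)c1ccc(O)cc1O` has a 2,4-dihydroxyphenyl there. For compound 3 the assay reports only a limit, > 100 ug/mL; this is the limit of > 100 ug/mL in this assay, at which 1 of the 3 values shown sits. Accordingly an at least 5.0-fold higher number from compound 1 to compound 3 (0.69 log units; beyond the scatter) and a number no lower from compound 2 to compound 3 (the limit leaves the size open), and compound 3 stands at the limit, no lower than any other number shown.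

Compound 4 `C/C(=N\NC(=O)COc1cccc2ccccc12)c1ccc(Br)cc1` is not yet measured. Its change from compound 3 is 4-bromophenyl in place of 2,4-dihydroxyphenyl on a carbon with a double bond to nitrogen. The hydroxyl groups leave and bromine enters. Among the measured compounds shown here, the steps that bear on this change are the ones that brought the dihydroxyphenyl in, an at least 5.0-fold higher number from compound 1 to compound 3 (0.69 log units; beyond the scatter) and a number no lower from compound 2 to compound 3 (the limit leaves the size open), both toward higher numbers, the first of them beyond the scatter. Running the other way, the step of an at least 2.0-fold lower number from compound 3 to compound 4 (0.30 log units; that floor lies within the scatter) is expected, toward a lower number and away from the limit. For compound 4 the estimate in this assay is 50 ug/mL, with a range from 20 ug/mL to 100 ug/mL.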

Compound 4, minimum cytotoxic concentration: 20 ug/mL
Estimate against measurement, compound 4: 2.5-fold (0.40 log units) above; measured number inside the range.
By their numbers in this assay, from the lowest: compounds 1 and 4 (each within the scatter of the next); then compound 2.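

In this assay, the 2,4-dihydroxyphenyl on the carbon with a double bond to nitrogen does not keep its high number once 4-bromophenyl takes its place, giving an at least 5.0-fold lower number from compound 3 to compound 4 (0.69 log units; beyond the scatter). Bromo in place of nitro on an aromatic carbon gives a 5.0-fold lower number from compound 2 to compound 4 (0.70 log units; beyond the scatter), so the number moves even when only the group on the phenyl changes and its printed position stays the same, which the earlier comparison of the two nitrophenyl compounds could not show. The third step reads no change at the digits printed from compound 1 to compound 4 (within the scatter), so a group printed at the 4 position does not by itself bring the higher number, since 4-bromophenyl here goes with the 3-nitrophenyl compound and not with the 4-nitrophenyl compound.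

Going by these compounds, the value of compound 3 is a limit, so the full size of the step away from it stays open: the limit of > 100 ug/mL in this assay, at which 1 of the 4 values shown sits. Also open is where a phenyl bearing an amine, a carboxylic acid or a single hydroxyl in this place would fall, and whether two hydroxyl groups are needed for the number to stand at that limit.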